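A Methoxy Swap in a Flat Series

The compounds below may be only part of what the source reports. "The series", "measured", "known", "first", "only" and "open" are said of these compounds alone.

In a functional assay on HepG2 cells (Homo sapiens) for cytotoxicity, read by MTT assay, with a stated time of 48 h (a higher number here means a weaker inhibitor, a lower number a stronger inhibitor), compound 1 `O=C(CSc1nnc(-c2ccncc2)o1)N/N=C/c1ccc(Cl)cc1` gives 15700 nM. Compound 2 `O=C(CSc1nnc(-c2ccncc2)o1)N/N=C/c1ccc([N+](=O)[O-])cc1` gives 17900 nM, and compound 3 `Cc1ccc(/C=N/NC(=O)CSc2nnc(-c3ccncc3)o2)cc1` gives 10000 nM. Compound 1 therefore stands among three numbers that all lie within the scatter of one another, with no real order among them.

Compound 4 `COc1cccc(/C=N/NC(=O)CSc2nnc(-c3ccncc3)o2)c1` has not been measured, and its difference from compound 1 is 3-methoxyphenyl in place of 4-chlorophenyl on a carbon with a double bond to nitrogen. Three measured swaps on an aromatic carbon bear on it: a 1.1-fold higher number from compound 1 to compound 2 (0.06 log units; within the scatter), a 1.6-fold lower number from compound 1 to compound 3 (0.20 log units; within the scatter) and a 1.8-fold lower number from compound 2 to compound 3 (0.25 log units; within the scatter). All three stay within the scatter, although none tests a 3-methoxyphenyl group.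

In this assay, the expected change is small, a 1.1-fold lower number from compound 1 to compound 4 (0.05 log units; within the scatter), and no step beyond the scatter is expected. For compound 4 the estimated value is 14000 nM, with an expected range of 7000 nM to 28000 nM.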

Compound 4, half-maximal inhibitory concentration: 9170 nM
Beside the measured number, compound 4's estimate is 1.5-fold (0.18 log units) above it, and the stated range covers the measured number.
By their numbers in this assay, from the lowest: compounds 4, 3, 1 and 2 (each within the scatter of the next).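

The swap to 3-methoxyphenyl gives a 1.7-fold lower number from compound 1 to compound 4 (0.23 log units; within the scatter) and a 1.1-fold lower number from compound 3 to compound 4 (0.04 log units; within the scatter) and also a 2.0-fold lower number from compound 2 to compound 4 (0.29 log units; within the scatter) in this assay for this compound. Among the compounds shown here, this is the first change here in both the group and its numbered place on the ring, from 4-chlorophenyl to 3-methoxyphenyl, and it brings in a hydrogen-bond acceptor, yet no step leaves the scatter. No supporting data bear on this result.

Going by these compounds, whether an amine or a carboxylic acid on this phenyl ring would move the number beyond the scatter stays open. So does the effect of replacing the phenyl ring with a longer chain.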